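The source may report more compounds than this note shows. Statements on the series, on what has been measured and on what is new or still open speak of the compounds shown alone.

In a functional assay on DU-145 cells (Homo sapiens) for antiproliferative activity, read by MTT assay, with a stated time of 48 h (a lower number here means a stronger inhibitor, a higher number a weaker inhibitor), compound 1 `Cc1cccn2cc(-c3nnc(-c4ccccc4)o3)nc12` gives 21800 nM and compound 2 `COc1ccc(-c2nnc(-c3cn4cccc(C)c4n3)o2)cc1` gives 10800 nM as the lower of the two numbers. Going by the values given here, the only measured step is a 2.0-fold lower number from compound 1 to compound 2 (0.31 log units; beyond the scatter) with methoxy in place of hydrogen on an aromatic carbon; it is modest but beyond the scatter. Compound 3 `Cc1cccn2cc(-c3nnc(-c4ccc(N(C)C)cc4)o3)nc12` keeps the core of compound 2 and carries dimethylamino in place of methoxy on an aromatic carbon, para to a large group (dimethylamino in place of methoxy on an aromatic carbon). Among the compounds with values here, no measured step covers this exchange directly. Going only by the modest size of a 2.0-fold lower number from compound 1 to compound 2 (0.31 log units; beyond the scatter) as the one step that bears on it, a step of similar or smaller size is expected in this assay with a slightly lower number the likelier direction. The expected step is a 1.2-fold lower number from compound 2 to compound 3 (0.08 log units; within the scatter) as an estimate. Compound 3 is expected at 9000 nM (estimated range 3500 nM to 23000 nM).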

Compound 3, half-maximal inhibitory concentration: 10800 nM
Estimate against measurement, compound 3: 1.2-fold (0.08 log units) below, within the range that was stated.
By their numbers in this assay, from the lowest: compounds 2 and 3 (each within the scatter of the next); then compound 1.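

In this assay, dimethylamino in place of methoxy on this aromatic carbon, para to a large group, gives no change at the digits printed from compound 2 to compound 3 (within the scatter) and so leaves the number where it stood, which the earlier pair could not show. Set against hydrogen, dimethylamino gives a 2.0-fold lower number from compound 1 to compound 3 (0.31 log units; beyond the scatter) at the same place, so two different groups now share a modest step from compound 1, and neither compound 2 nor compound 3 goes against this. Nothing measured here accounts for why the two groups read alike.

As far as these compounds go, whether fluorine, a carboxylic acid or a longer chain such as butoxy at this carbon would follow compounds 2 and 3 stays open. So does whether a larger step is reachable at this place at all, since only these two groups bear on it.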